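Moving the hydroxyl around the phenyl ring

The source may report more compounds than this note shows. Statements on the series, on what has been measured and on what is new or still open speak of the compounds shown alone.

Measured compounds:
- compound 1 `C#CCSc1nc(NCCC(C)C)c2ccncc2n1`: in a functional assay on PC-3 cells (Homo sapiens) for inhibition, read by MTT assay, with a stated time of 72 h (on this read-out higher numbers stand for weaker inhibition and lower numbers for stronger inhibition), compound 1 gives only a limit of the assay, > 80000 nM.
- compound 2 `C#CCSc1nc(Nc2ccccc2O)c2ccncc2n1`: in this assay compound 2 gives 18700 nM.

Compound 2 holds the only real number shown. The value of compound 1 is a limit of the assay. Compound 3 `C#CCSc1nc(Nc2ccc(O)cc2)c2ccncc2n1` differs from compound 2 by 4-hydroxyphenyl in place of 2-hydroxyphenyl on a nitrogen on an aromatic ring. Within the data shown here, the single measured step, an at least 4.2-fold lower number from compound 1 to compound 2 (0.63 log units; beyond the scatter), exchanged a chain for a ring and so bears only loosely on shifting a hydroxyl within the same ring. No step beyond the scatter is expected in this assay. Compound 3 is estimated at 18000 nM, between 6000 nM and 60000 nM. That expectation amounts to a 1.0-fold lower number from compound 2 to compound 3 (0.02 log units; within the scatter).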

Compound 3, half-maximal inhibitory concentration: > 80000 nM
Compound 3: no number, only a limit (the forecaster's own chance of this, stated with the estimate: 10%); middle value at least 4.4-fold (0.64 log units) from the limit.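

Shifting only the hydroxyl, with the same atoms on the same nitrogen, gives an at least 4.2-fold higher number from compound 2 to compound 3 (0.63 log units; beyond the scatter) in this assay. The earlier step swapped a chain for a ring, whereas this one shows that the place of the hydroxyl on the phenyl ring matters, and that the 2-hydroxyphenyl group is the better of the two. Compound 1 and compound 3 both give only a limit, so the step between them cannot be read: the limit of > 80000 nM in this assay, at which 2 of the 3 values shown sit.

Still open, from the compounds shown here alone, is whether an amine or a methoxy group in place of the hydroxyl of compound 2 would keep its inhibition.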